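Swapping a para tert-butyl for chloro on the benzyl arm

A few compounds are considered here, and "the series" means these few. Any claim that something is new, unique, unknown or untested is made for them only; others in the source may bear on it.

Of the compounds shown here, two sharing one core have been measured. Compound 1 `CCN(CC)Cc1ccc2nc(NC(=O)N/N=C/c3cn(Cc4ccccc4)c4ccccc34)sc2c1` carries an unsubstituted benzyl group; in a functional assay on NCI-H460 cells (Homo sapiens) for cytotoxicity, read by MTT assay, with a stated time of 72 h (a lower number here means a stronger inhibitor, a higher number a weaker inhibitor), compound 1 gives 450 nM. Compound 2 `CCN(CC)Cc1ccc2nc(NC(=O)N/N=C/c3cn(Cc4ccc(C(C)(C)C)cc4)c4ccccc34)sc2c1` carries a tert-butyl on that benzyl ring, and in this assay compound 2 gives 1670 nM. Within the data shown here, the only step within this pair, a 3.7-fold higher number from compound 1 to compound 2 (0.57 log units; beyond the scatter), is the one measured change, and it places compound 2 at the highest number of the two.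

Compound 3 `CCN(CC)Cc1ccc2nc(NC(=O)N/N=C/c3cn(Cc4ccc(Cl)cc4)c4ccccc34)sc2c1` differs from compound 2 in one place: chloro in place of tert-butyl on an aromatic carbon. Among the measured compounds shown here, no measured step covers chloro directly, so only the step from compound 1 to compound 2 bears on the question; it shows that adding tert-butyl at this position weakened the compound beyond the scatter, while the hydrogen of compound 1 gave the stronger number. Chloro in place of tert-butyl is therefore expected to move the number back part of the way toward compound 1, with the step of a 2.1-fold lower number from compound 2 to compound 3 (0.32 log units; beyond the scatter) expected to be modest. Compound 3 is estimated at 800 nM, with a range from 350 nM to 1900 nM.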

Compound 3, half-maximal inhibitory concentration: 370 nM
Compound 3: middle estimate off by 2.2-fold (0.33 log units), on the high side; measured number inside the range.
By their numbers in this assay, from the lowest: compounds 3 and 1 (each within the scatter of the next); then compound 2.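

Exchanging the 4-(tert-butyl)benzyl group for 4-chlorobenzyl gives a 4.5-fold lower number from compound 2 to compound 3 (0.65 log units; beyond the scatter) in this assay and so shows that the loss seen with tert-butyl does not come with every group on this ring carbon. Set against the unsubstituted benzyl of the shared core, chloro gives a 1.2-fold lower number from compound 1 to compound 3 (0.09 log units; within the scatter) and so cannot be told apart from hydrogen here, which leaves compound 2 as the only one of the three that stands clearly apart. These numbers show that tert-butyl and chloro behave differently at this position, but nothing available explains the difference.

Still open, on these data alone, is how the response runs across other groups at this position: methyl, isopropyl and methoxy would show whether the result for tert-butyl is confined to that group or begins with smaller carbon groups, while an amine or a carboxylic acid would test a very different kind of substituent. As far as these compounds go, it is also open whether chloro would give a similar number on another carbon of this ring, and whether the closeness of chloro and hydrogen would hold in other cell lines.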